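The compounds below may be only part of what the source reports. "The series", "measured", "known", "first", "only" and "open" are said of these compounds alone.

Measured so far in an assay on cells for inhibition of Voltage-dependent T-type calcium channel subunit alpha-1H (Homo sapiens), read by FLIPR and calcium flux, with stated times of 600 s and 300 s; a higher number here means a weaker inhibitor, a lower number a stronger inhibitor: compound 1 `N=C(N)NCCCOc1ccc(CNc2nc3ccc(Oc4cccc(C(F)(F)F)c4)cc3s2)cc1`, with 270000 nM; compound 2 `NCCCOc1ccc(CNc2nc3ccc(Oc4cccc(C(F)(F)F)c4)cc3s2)cc1`, with 171000 nM.

Of these two numbers, compound 1 has the larger one, but a 1.6-fold lower number from compound 1 to compound 2 (0.20 log units; within the scatter) lies within the scatter, so the two compounds cannot be told apart in this assay. Compound 3 `N=C(N)NCCCOc1ccc(CNc2nc3ccc(Oc4ccc(O)cc4)cc3s2)cc1` keeps everything else of compound 1 and changes only the aryl ether: 4-hydroxyphenyl in place of 3-(trifluoromethyl)phenyl on an oxygen on an aromatic ring. Among the measured compounds shown here, no measured step touches this position; the single measured step concerns the amine end instead, so the direction of the change is unknown. Compound 3 is therefore expected near compound 1, with a 1.1-fold higher number from compound 1 to compound 3 (0.05 log units; within the scatter) and a wide range: estimated 300000 nM, between 100000 nM and 1000000 nM.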

Compound 3, half-maximal inhibitory concentration: 319000 nM
The estimate for compound 3 lay 1.1-fold (0.03 log units) below the measured number; the measured number falls inside the stated range.
By their numbers in this assay, from the lowest: compounds 2, 1 and 3 (each within the scatter of the next).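

This position now has a measured step of its own: in this assay, 4-hydroxyphenyl in place of 3-(trifluoromethyl)phenyl on an oxygen on an aromatic ring gives a 1.2-fold higher number from compound 1 to compound 3 (0.07 log units; within the scatter). Compound 1 and compound 3 therefore cannot be told apart, even though the entering group carries a hydrogen-bond donor and a hydrogen-bond acceptor and the leaving group carries neither. On these data alone, whether a different group on that oxygen, such as an aminophenyl or a carboxyphenyl, would give a number beyond the scatter of compound 1 remains open. Nothing available explains why this change leaves the two compounds indistinguishable.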